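The compounds below may be only part of what the source reports. "The series", "measured", "known", "first", "only" and "open" are said of these compounds alone.

Three compounds share one core and differ in a single group on the aromatic ring: compound 1 `CC1=CC[C@@H]([C@@](C)(O)CCCC(C)(C)NC(=S)N/N=C\c2ccc(C)cc2)CC1`, compound 2 `CC1=CC[C@@H]([C@@](C)(O)CCCC(C)(C)NC(=S)N/N=C\c2ccc(O)cc2)CC1` and compound 3 `CC1=CC[C@@H]([C@@](C)(O)CCCC(C)(C)NC(=S)N/N=C\c2ccc(N(C)C)cc2)CC1`. In a functional assay on NCI-H460 cells (Homo sapiens) for cytotoxicity, read by sulforhodamine B assay (on this read-out higher numbers stand for weaker inhibition of growth and lower numbers for stronger inhibition of growth), compound 3 gives > 100000 nM, which is a limit and not a number. Compound 1 gives > 100000 nM, also a limit. Compound 3 therefore stands with compound 1 at the limit of > 100000 nM in this assay, at which 2 of the 3 values shown sit. Compound 2 gives a true number, 20700 nM.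

Compound 4 `CC1=CC[C@@H]([C@@](C)(O)CCCC(C)(C)NC(=S)N/N=C\c2ccc(Cl)cc2)CC1` carries chloro in place of dimethylamino on an aromatic carbon. Two measured steps show that this group can matter. Hydroxy in place of methyl gave an at least 4.8-fold lower number from compound 1 to compound 2 (0.68 log units; beyond the scatter), while dimethylamino in place of hydroxy gave an at least 4.8-fold higher number from compound 2 to compound 3 (0.68 log units; beyond the scatter). Dimethylamino in place of methyl gave a step that the two limits leave unreadable from compound 1 to compound 3. Only compound 2 has so far reached a number, so at best a modest fall is expected in this assay, and another limit is quite possible. The estimated change is an at least 1.6-fold lower number from compound 3 to compound 4 (0.22 log units; that floor lies within the scatter). For compound 4, the expected value is 60000 nM, within an estimated range from 20000 nM to 100000 nM.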

Compound 4, concentration for total growth inhibition: > 100000 nM
Compound 4: only a limit was reported (the forecaster's own chance of this, stated with the estimate: 50%); at least 1.6-fold (0.22 log units) between middle value and limit.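

In this assay, chloro on this aromatic carbon, para to a large group, does not give the true number seen with hydroxy: chloro in place of hydroxy gives an at least 4.8-fold higher number from compound 2 to compound 4 (0.68 log units; beyond the scatter). The steps to compound 4 from compound 1 and from compound 3 cannot be read, as both ends of each are limits. Hydroxy thus remains the only group of the four at this position with a true number, while methyl, dimethylamino and chloro all share one limit: the limit of > 100000 nM in this assay, at which 3 of the 4 values shown sit.

Going by these compounds, whether an amine, a carboxylic acid or a methoxy group at this position would also reach a true number remains open. The compounds shown also do not tell what sets hydroxy apart from the other three groups.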